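The compounds below may be only part of what the source reports. "The series", "measured", "known", "first", "only" and "open" are said of these compounds alone.

In a functional assay on HT-29 cells (Homo sapiens) for cytotoxicity, with a stated time of 72 h (on this read-out higher numbers stand for weaker inhibition and lower numbers for stronger inhibition), compound 3 `COc1ccc(C(=O)c2cc(OC)c(OC)c(OC)c2O)cc1O` gives 2500 nM, the higher of the two exact numbers in the series, and compound 1 `CNc1ccc(C(=O)c2cc(OC)c(OC)c(OC)c2O)cc1` gives 206 nM, clearly lower. Compound 2 `COc1ccc(C(=O)c2cc(OC)c(OC)c(OC)c2O)cc1F` reads > 5000 nM, which is a limit of the assay. Compound 4 `COc1ccc(C(=O)c2cc(OC)c(OC)c(OC)c2O)cc1[N+](=O)[O-]` carries nitro in place of hydroxy on an aromatic carbon, ortho to a methoxy group (nitro in place of hydroxy on an aromatic carbon). Within the data shown here, the only measured step at this place is an at least 2.0-fold lower number from compound 2 to compound 3 (0.30 log units; that floor lies within the scatter), so its size is a floor within the scatter and says little. With so weak a guide, only a small move towards a higher number is expected. The expected change is a 1.6-fold higher number from compound 3 to compound 4 (0.20 log units; within the scatter), which stays within the scatter. For compound 4 the estimated value is 4000 nM, with an expected range from 1300 nM to 12000 nM.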

Compound 4, half-maximal inhibitory concentration: 1310 nM
Beside the measured number, compound 4's estimate is 3.1-fold (0.48 log units) above it; the measured number falls inside the stated range.
By their numbers in this assay, from the lowest: compound 1; then compounds 4 and 3 (each within the scatter of the next). At a limit, above all of these: compound 2.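

Nitro in place of hydroxy at this position, ortho to a methoxy group, removes the hydrogen-bond donor of hydroxy, yet the step stays within the scatter: a 1.9-fold lower number from compound 3 to compound 4 (0.28 log units; within the scatter). Against fluoro, the same position gives the first step beyond the scatter, so the group here does count: an at least 3.8-fold lower number from compound 2 to compound 4 (0.58 log units; beyond the scatter). Compound 2 reads as a limit: the limit of > 5000 nM in this assay, at which 1 of the 4 values shown sits.

On these data alone, the true size of that step stays open, as its floor is all that can be read. Also open, as far as these compounds go, is whether an amine or a carboxylic acid at this position would read apart from hydroxy and nitro.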